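Phenyl in place of isopropyl: notes on compound 3

The source may hold more compounds than are shown below. What is called first, only, known or untested is meant among the compounds shown, and "the series" means these compounds.

In a functional assay (aorta) with Rattus norvegicus as the target (on this read-out higher numbers stand for weaker inhibition and lower numbers for stronger inhibition), compound 1 `CC(C)c1cn2ccccc2c1S(=O)(=O)c1ccc(OCCCNCc2ccccc2)cc1` gives 22.8 nM and compound 2 `CCCCN(CCCC)CCCOc1ccc(S(=O)(=O)c2c(C(C)C)cn3ccccc23)cc1` gives 21.6 nM. Compound 2 therefore stands level with compound 1, the two numbers lying within the scatter of each other. Among the measured compounds shown here, the one measured step, a 1.1-fold lower number from compound 1 to compound 2 (0.02 log units; within the scatter), exchanges benzylamino for dibutylamino on the chain and is within the scatter.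

Compound 3 `CCCCN(CCCC)CCCOc1ccc(S(=O)(=O)c2c(-c3ccccc3)cn3ccccc23)cc1` keeps the dibutylamino chain of compound 2 and differs elsewhere: phenyl in place of isopropyl on an aromatic carbon. In words, this is phenyl in place of isopropyl on an aromatic carbon. For the measured compounds named here, no measured step touches that carbon, so the data offer no direct precedent for its size. A modest move to a higher number in this assay is expected, though only loosely, and the range is kept wide. The expected change is a 2.3-fold higher number from compound 2 to compound 3 (0.36 log units; beyond the scatter). The estimated value for compound 3 is 50 nM, with an expected range of 12 nM to 200 nM.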

Compound 3, half-maximal inhibitory concentration: 1620 nM
Beside the measured number, compound 3's estimate is 32-fold (1.51 log units) below it, and the stated range ends below it.
By their numbers in this assay, from the lowest: compounds 2 and 1 (each within the scatter of the next); then compound 3.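

In this assay, among the compounds shown here, the aromatic carbon that carries isopropyl in compound 2 responds far more strongly than the chain amine does: a 75-fold higher number from compound 2 to compound 3 (1.88 log units; beyond the scatter), against a 1.1-fold lower number from compound 1 to compound 2 (0.02 log units; within the scatter) for the only earlier exchange. With the dibutylamino chain held fixed, phenyl in place of isopropyl brings a six-membered aromatic ring of carbon only, adds no hydrogen-bond donors or acceptors, and is a large step towards weaker inhibition. Nothing at hand gives a reason for the size of this step.

From the compounds shown here alone, whether a methyl or cyclopropyl group on this carbon would stay close to compound 2 remains open, so the range of groups this position accepts is undefined. Also open, going by these compounds, is whether phenyl here would cost as much with the benzylamino chain of compound 1.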